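The source may hold more compounds than are shown below. What is called first, only, known or untested is meant among the compounds shown, and "the series" means these compounds.

Notes on the series. Compound 1 `FC(F)(F)c1cc(NC[C@H]2CCCN2)c2cn[nH]c2c1` carries a trifluoromethyl group on the shared core and a (pyrrolidin-2-yl)methyl chain on the ring nitrogen. In a functional assay on Jurkat cells (Homo sapiens) for inhibition, read by MTT assay, with a stated time of 24 h (on this read-out higher numbers stand for weaker inhibition and lower numbers for stronger inhibition), compound 1 returns only a limit, > 20000 nM, not a number. Compound 2 `CS(=O)(=O)c1ccc(CNc2cc(C(F)(F)F)cc3[nH]ncc23)c([N+](=O)O)c1` also returns only a limit in this assay, > 20000 nM. Among the compounds with values here, both values therefore sit at the limit of > 20000 nM in this assay, at which 2 of the 2 values shown sit, so compound 1 cannot be placed relative to compound 2 at all; the series so far shows no measurable inhibition.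

Compound 3 `FC(F)(F)c1cc(NC[C@@H]2CCCCN2)c2cn[nH]c2c1` is not yet measured. It differs from compound 1 in one place: piperidin-2-yl in place of pyrrolidin-2-yl on a saturated chain carbon bound to a nitrogen on an aromatic ring. Within the data shown here, with no measured step of this kind available and both known values at the limit, the step from compound 1 to compound 3 is expected to be none beyond the scatter, a step that the limit leaves unreadable from compound 1 to compound 3. Compound 3 is accordingly expected to give about 30000 nM in this assay, within 10000 nM to 100000 nM, most likely reported again as a limit.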

Compound 3, half-maximal inhibitory concentration: > 20000 nM
Compound 3 was reported as a limit; the forecaster's own chance of this, stated with the estimate: 80%; the middle value is on the limit's open side.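

Within the data shown here, compound 1 and compound 3 both return only limits, so no step between them can be read: the limit of > 20000 nM in this assay, at which 3 of the 3 values shown sit. The compounds shown leave open whether any group on the shared core gives a measured number rather than a limit, and how the pyrrolidin-2-yl and piperidin-2-yl chains would then compare.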